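The compounds below may be only part of what the source reports. "The series", "measured", "known", "first", "only" and "open" are said of these compounds alone.

Three compounds of the series, all carrying the same core, have been run in a functional assay on IMR-32 cells (Homo sapiens) for cytotoxicity, read by MTT assay, tested at 60 ug/mL; on this read-out lower numbers stand for less inhibition and higher numbers for more inhibition at the one concentration tested (going by the name of the read-out). Compound 1 `CCCCNC(=O)CCC(NS(=O)(=O)c1cc(Cl)ccc1Cl)C(=O)NCCCC` gives 15.8%. Compound 2 `CC(C)CNC(=O)CCC(NS(=O)(=O)c1cc(Cl)ccc1Cl)C(=O)NCC(C)C` gives 20.4%, and compound 3 `CCCCCCNC(=O)CCC(NS(=O)(=O)c1cc(Cl)ccc1Cl)C(=O)NCCCCCC` gives 12.4%. Compound 2 stands on the largest of the three numbers, but both compound 1 and compound 3 lie within the scatter of it, so the three read-outs cannot be ordered.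

Compound 4 `CC(C)CNC(=O)CCC(NS(=O)(=O)c1ccc(Br)cc1)C(=O)NCC(C)C` has not yet been measured. It differs from compound 2 in one place: 4-bromophenyl in place of 2,5-dichlorophenyl on a sulfonyl sulfur. Within the data shown here, no measured pair shows the effect of such a change, so the step is estimated as a number 3.4 percentage points lower from compound 2 to compound 4 (within the scatter), that is none beyond the scatter in this assay. Compound 4 is expected to give 17%, in the range 7% to 30%.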

Compound 4, a percentage reported as inhibition, at one concentration (the size of the read-out at that concentration, not a potency): 17.1%
Compound 4: middle estimate off by 0.1 percentage points, on the low side, within the range that was stated.
By their numbers in this assay, from the lowest: compounds 3, 1, 4 and 2 (each within the scatter of the next).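

In this assay the change to 4-bromophenyl in place of 2,5-dichlorophenyl on a sulfonyl sulfur gives a number 3.3 percentage points lower from compound 2 to compound 4 (within the scatter) and so shows that this exchange of substituted phenyl groups does not separate the two compounds. Compounds 1 to 3 varied only the amide chains and said nothing about this place. Nothing at hand offers an explanation of this result.

Still open, from the compounds shown here alone, is whether an aminophenyl or carboxyphenyl group, or a longer alkyl chain in place of the phenyl, on the sulfonyl sulfur would move the read-out beyond the scatter. The 4-bromophenyl group also remains to be seen with the butyl and hexyl amides.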